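This account rests on a few compounds, and the source may have more. Where it says the series, first, only, none or still open, it means among the compounds named here.

In an assay on H9c2 cells for inhibition of tumor necrosis factor receptor superfamily member 6 (Rattus norvegicus), with stated times of 30 min and 6 h (a higher number here means that more compound is needed for the effect, a lower number that less compound is needed), compound 3 `COC(=O)c1ccsc1NC(=O)CSc1ccccc1` gives 724 nM, the second highest of the three numbers, yet within the scatter of both others: compound 2 `CN(C)C(=O)c1sccc1NC(=O)CSc1ccc(Br)cc1` gives 851 nM, and compound 1 `COC(=O)c1sccc1NC(=O)CSc1ccc(Br)cc1` gives 427 nM. Among the compounds with values here, the single measured step, a 2.0-fold higher number from compound 1 to compound 2 (0.30 log units; within the scatter), concerns the substituent on the carbonyl carbon and says nothing about a bromine. Compound 4 `COC(=O)c1ccsc1NC(=O)CSc1ccc(Br)cc1` differs from compound 3 by bromo in place of hydrogen on an aromatic carbon. Within the data shown here, no measured pair isolates this change; compound 1 and compound 3 differ in two places, and their two values lie within the scatter of each other. The step from compound 3 to compound 4 is therefore expected to stay within the scatter, a 1.3-fold lower number from compound 3 to compound 4 (0.12 log units; within the scatter). Compound 4 is estimated at 550 nM, with a range from 220 nM to 1400 nM.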

Compound 4, half-maximal effective concentration: 759 nM
Beside the measured number, compound 4's estimate is 1.4-fold (0.14 log units) below it; low and high end bracket the measured number.
By their numbers in this assay, from the lowest: compounds 1, 3, 4 and 2 (each within the scatter of the next).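

Phenyl to 4-bromophenyl, with the bromo para to a large group, can now be read directly in this assay as a 1.0-fold higher number from compound 3 to compound 4 (0.02 log units; within the scatter). On the core of compound 3, this position therefore tolerates a bromine with no change beyond the scatter. Nothing available explains this result.

The compounds shown leave open how an amine, a carboxylic acid or a longer chain would read at this same place. They also leave open whether phenyl to 4-bromophenyl would read the same way on the core of compound 1.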